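The source may hold more compounds than are shown below. What is called first, only, known or untested is meant among the compounds shown, and "the series" means these compounds.

Compound 1 `COc1ccc(N)c(C2=NN(C(=O)C3CCC3)C(C)(C)S2)c1`, in an assay on isolated protein for inhibition of Nitric oxide synthase, inducible (Homo sapiens), read by scintillation counting, with a stated time of 30 min, tested at 50 uM (a lower number here means less inhibition, a higher number more inhibition at the concentration tested (going by the name of the read-out)), compound 1 gives 57.8%.
Compound 2 `CCCC(=O)N1N=C(c2ccccc2N)SC1(C)C`, in this assay compound 2 gives 35.2%.

Of the two measured compounds, compound 2 stands lowest, and compound 1 sits higher by a gap beyond the usual scatter. Compound 3 `CC1(C)SC(c2ccccc2N)=NN1C(=O)C1CCC1` has not yet been measured. It differs from compound 2 in one place: cyclobutyl in place of propyl on a carbonyl carbon. Among the measured compounds shown here, no measured pair isolates this single change, so its effect is unknown. The expected step is a number 6.8 percentage points higher from compound 2 to compound 3 (within the scatter), an estimate that allows a modest rise or no step beyond the scatter. Compound 3 is therefore estimated at 42%, within 25% to 60%.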

Compound 3, a percentage reported as inhibition, at one concentration (the size of the read-out at that concentration, not a potency): 46.9%
Compound 3: the middle estimate sits 4.9 percentage points below what was measured; low and high end bracket the measured number.
By their numbers in this assay, from the lowest: compound 2; then compound 3; then compound 1.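

On a carbonyl carbon, cyclobutyl in place of propyl gives a number 11.7 percentage points higher from compound 2 to compound 3 (beyond the scatter) in this assay, so this site responds when the open chain gives way to a small ring of carbon. Compound 3 also isolates a second change, as hydrogen in place of methoxy on an aromatic carbon gives a number 10.9 percentage points lower from compound 1 to compound 3 (beyond the scatter), so that group counts too. No measurement here explains either step.

On these data alone, whether cyclopentyl or phenyl on the carbonyl carbon would give a higher or lower number remains open. So does whether an amine or a fluorine in place of methoxy would match that group.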